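Phenyl-to-methyl exchange across three measured analogues and one pending

This account rests on a few compounds, and the source may have more. Where it says the series, first, only, none or still open, it means among the compounds named here.

Of the compounds shown here, three have been measured in an assay on isolated protein for inhibition of RAC-beta serine/threonine-protein kinase (Homo sapiens), read by mobility shift assay, tested at 30 uM; a lower number here means less inhibition, a higher number more inhibition at the concentration tested (going by the name of the read-out). Compound 1 `Cc1cc2nn(-c3ccccc3)c(N)c2c(=O)[nH]1` gives 1%. Compound 2 `Nc1c2c(=O)[nH]c(-c3ccccc3)cc2nn1-c1ccccc1` gives -1%. Compound 3 `Cc1cc2nc(-c3ccccc3)nc(N)c2c(=O)[nH]1` gives 2%. All three numbers lie within the usual scatter of one another, so no order among them is drawn. Among the measured compounds shown here, the one counted change among the measured compounds, (methyl in place of phenyl on an aromatic carbon), made a step of a number 2 percentage points higher from compound 2 to compound 1 (within the scatter). Compound 3 and compound 2 differ in their cores, and that difference is not broken down here.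

Compound 4 `Cc1nc(N)c2c(=O)[nH]c(C)cc2n1` is still to be measured in this assay. It differs from compound 3 by methyl in place of phenyl on an aromatic carbon. Against the measured change, this one sits on a six-membered aromatic ring with 2 nitrogen, between two ring nitrogen atoms and meta to an amino group, whereas the earlier one sits on a ring with 1 nitrogen, next to the ring nitrogen and meta to a group of 1 heavy atom; it is the same kind of change, not the same. Resting on compound 3 at 2% and on the earlier step of a number 2 percentage points higher from compound 2 to compound 1 (within the scatter), the expected step is no change at the digits printed from compound 3 to compound 4 (within the scatter). Compound 4 is estimated at 2%, between -8% and 11%.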

Compound 4, a percentage reported as inhibition, at one concentration (the size of the read-out at that concentration, not a potency): 2%
The estimate for compound 4 equals the measured number at the digits printed; measured number inside the range.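

Methyl in place of phenyl on an aromatic carbon gives no change at the digits printed from compound 3 to compound 4 (within the scatter) in this assay. Set beside the earlier step, the change reads alike on the two cores: the same change on two cores in this assay, a number 2 percentage points higher (within the scatter) from compound 2 to compound 1 and no change at the digits printed (within the scatter) from compound 3 to compound 4, 2 percentage points apart, within the scatter of two such steps

Among the compounds shown here, this agreement is between two steps that stay within the scatter, with all four compounds showing little inhibition at the concentration tested, so it shows only that the exchange produced no readable step on either core and does not show that a shared effect carries from one core to the other or that the same would hold for a compound with clear inhibition.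

The compounds shown carry only methyl or phenyl at the exchanged aromatic carbon, so it stays open whether an amine, a carboxylic acid or a longer chain there would bring inhibition beyond the scatter. Also open, as far as these compounds go, is whether the phenyl-to-methyl exchange would give a readable step on a compound with clear inhibition in this assay.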